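Trimming a Side Chain at the Limit of the Assay

This account rests on a few compounds, and the source may have more. Where it says the series, first, only, none or still open, it means among the compounds named here.

In a functional assay on NALM-6 cells (Homo sapiens) for cytotoxicity, with a stated time of 72 h (on this read-out lower numbers stand for an effect already at smaller amounts and higher numbers for an effect only at larger amounts of compound), compound 1 `C=C[C@@](C)(/C=C/c1ccc(OS(=O)(=O)c2ccc(C)cc2)cc1)CCC=C(C)C` gives > 43400 nM as a limit and not a number. Compound 2 `C=C[C@@](C)(/C=C/c1ccc(O)cc1)CCC(O)C(C)(C)O` also gives only a limit with > 43400 nM as its entry. Compound 2 thus stands at the limit of > 43400 nM in this assay, at which 2 of the 2 values shown sit, and offers no number to start from. Compound 3 `C=C[C@@](C)(/C=C/c1ccc(O)cc1)CCCO` differs from it by one change, (hydrogen in place of 1-hydroxy-1-methylethyl on a saturated chain carbon bound to an oxygen on a saturated carbon and a saturated chain carbon), with hydrogen in place of 1-hydroxy-1-methylethyl. The expected a number no higher from compound 2 to compound 3 (the limit leaves the size open) is none beyond the scatter in either direction. Compound 3 is expected at 43400 nM with an estimated range from 20000 nM to 60000 nM as the upper end.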

Compound 3, half-maximal effective concentration: > 43400 nM
Compound 3 gave a limit, no number; the forecaster's own chance of this, stated with the estimate: 85%; the middle value sits exactly at the limit.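

Among these compounds, compound 2 and compound 3 both give only a limit, not a number, so no step between them can be read. The compounds shown leave open whether hydrogen in place of 1-hydroxy-1-methylethyl alters the effect at all.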